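Amine variation on the shared core in MCF7 inhibition

The source may hold more compounds than are shown below. What is called first, only, known or untested is meant among the compounds shown, and "the series" means these compounds.

Measured compounds:
compound 1, `Cc1ccc(NC2=CC(=O)c3nc4n(c3C2=O)[C@H]2OC[C@@H](O)[C@H]2OC4)cc1C`, gives 2080 nM in a functional assay on MCF7 cells (Homo sapiens) for inhibition, read by sulforhodamine B assay; a lower number here means a stronger inhibitor, a higher number a weaker inhibitor.
compound 2, `O=C1C=C(NC2CCCCC2)C(=O)c2c1nc1n2[C@H]2OC[C@@H](O)[C@H]2OC1`, is reported in this assay only as a limit of the assay, > 8000 nM.

Going by the values given here, the single measured step, an at least 3.8-fold higher number from compound 1 to compound 2 (0.58 log units; beyond the scatter), is the exchange of the aryl group on the amine nitrogen for a saturated ring. Its size is only a lower bound because of the limit of > 8000 nM in this assay, at which 1 of the 2 values shown sits; the true loss may be larger. Compound 2 therefore stands at the weak end of the two numbers shown, and its position is known only as a limit.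

Compound 3, `CCCN(CCC)C1=CC(=O)c2nc3n(c2C1=O)[C@H]1OC[C@@H](O)[C@H]1OC3`, is the next change: dipropylamino in place of cyclohexylamino on a double-bonded ring carbon. No measured step covers the loss of the amine hydrogen or the opening of the ring into two chains, so the one step shown does not bear on it directly; it only shows that a non-aromatic substituent on this nitrogen already sits beyond the limit. With compound 2 at the limit, no step size can be expected with confidence, and the estimated step that the limit leaves unreadable from compound 2 to compound 3 is taken as none beyond the scatter. Compound 3 is thus expected at about 12000 nM, within 4000 nM to 40000 nM, most likely again reported as a limit.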

Compound 3, half-maximal inhibitory concentration: > 16000 nM
Compound 3: no number, only a limit; the forecaster's own chance of this, stated with the estimate: 65%; at least 1.3-fold (0.12 log units) between middle value and limit.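

In this assay compound 3 is reported only as a limit of the assay, > 16000 nM. Dipropylamino in place of the (3,4-dimethylphenyl)amino group gives an at least 7.6-fold higher number from compound 1 to compound 3 (0.88 log units; beyond the scatter), so a second non-aromatic substituent, this one with no ring and no amine hydrogen, also reads on the weak side of the aryl compound, as cyclohexylamino did. The step from cyclohexylamino to dipropylamino cannot be read, so neither the loss of the amine hydrogen nor the opening of the ring can be sized on its own: the limit of > 16000 nM in this assay, at which 1 of the 3 values shown sits.

The compounds shown leave open whether the better reading of compound 1 belongs to the aromatic ring itself or to its two methyl groups, a question that a plain phenylamino group would address. Also open, from the compounds shown here alone, is whether a benzylamino group, which keeps an aromatic ring on a saturated carbon attached to the amine nitrogen, gives a true number in this assay or falls to a limit as well.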